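This account rests on a few compounds, and the source may have more. Where it says the series, first, only, none or still open, it means among the compounds named here.

Among the measured compounds shown here, compound 1, `O=[N+]([O-])c1ccc2nc(O)c(-c3ccccc3)c(O)c2c1`, is the only compound of this set with a number in hand: in an assay on isolated protein for inhibition of fatty acid synthase (Rattus norvegicus) (on this read-out higher numbers stand for weaker inhibition and lower numbers for stronger inhibition), compound 1 gives 550 nM, so it stands alone with nothing to rank it against. For compound 2, `N#Cc1cc(Cl)c2nc(O)c(-c3ccccc3)c(O)c2c1`, the outcome in this assay is "not determined" (no result reported), leaving no second point of reference. Compound 3, `Oc1nc2ccc(C(F)(F)F)cc2c(O)c1-c1ccccc1`, differs from compound 1 by trifluoromethyl in place of nitro on an aromatic carbon. For the measured compounds named here, no measured pair in this set shows what such an exchange does. Compound 3 is therefore expected to stay close to compound 1, with the estimated step of a 1.5-fold higher number from compound 1 to compound 3 (0.16 log units; within the scatter) leaning only slightly toward weaker inhibition and not clearly beyond the scatter. Compound 3 is estimated at 800 nM, within a range from 250 nM to 2500 nM.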

Compound 3, half-maximal inhibitory concentration: > 15000 nM
Compound 3 was reported as a limit; the forecaster's own chance of this, stated with the estimate: 10%; at least 18-fold (1.27 log units) between middle value and limit.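

This aromatic carbon, meta to a fused ring and para to a fused ring, proves sensitive in this assay: trifluoromethyl in place of nitro gives an at least 27-fold higher number from compound 1 to compound 3 (1.43 log units; beyond the scatter). Among the compounds shown here, the two groups are therefore not interchangeable here, which no earlier compound could show. The entry for compound 3 is a limit of the assay and not a number: the limit of > 15000 nM in this assay, at which 1 of the 3 values shown sits.

On these data alone, what remains open is whether an amine or a carboxylic acid on this carbon would keep the inhibition seen with compound 1. The compounds shown also do not tell why this exchange costs so much.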